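Swapping Fluoro for Methoxy on the Quinoline Core

A few compounds are considered here, and "the series" means these few. Any claim that something is new, unique, unknown or untested is made for them only; others in the source may bear on it.

Compound 2, `CC1CCN(c2c(S(=O)(=O)c3cccc(F)c3)cnc3ccc(F)cc23)CC1`: 76%
Compound 1, `COc1ccc2ncc(S(=O)(=O)c3ccc(OC)c(Cl)c3)c(N3CCC(C)CC3)c2c1`: 21%

Of the compounds shown here, two have been measured in an assay on isolated protein for displacement of a labelled ligand from metabotropic glutamate receptor 5 (Homo sapiens), with a stated time of 60 min, tested at 1 uM; on this read-out lower numbers stand for less inhibition and higher numbers for more inhibition at the one concentration tested (going by the name of the read-out). Compound 2 gives the higher of the two numbers, and compound 1 stands well below it, a gap beyond the usual scatter. Within the data shown here, no pair of compounds differing in only one place has been measured, so the two values do not isolate any single change.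

Compound 3, `COc1ccc2ncc(S(=O)(=O)c3cccc(F)c3)c(N3CCC(C)CC3)c2c1`, is not yet measured. It differs from compound 2 by methoxy in place of fluoro on an aromatic carbon. Compound 1 also carries methoxy on its core yet differs in other places as well, so its value cannot be credited to that group alone. A moderate drop in this assay is nonetheless expected, a number 21 percentage points lower from compound 2 to compound 3 (beyond the scatter). This rests on compound 1, which carries the same methoxy on its core and gives 21%. Compound 3 is expected to give about 55%, within 25% to 80%.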

Compound 3, a percentage reported as inhibition, at one concentration (the size of the read-out at that concentration, not a potency): 68%
Estimate against measurement, compound 3: 13 percentage points below; low and high end bracket the measured number.
By their numbers in this assay, from the lowest: compound 1; then compounds 3 and 2 (each within the scatter of the next).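

In this assay, methoxy in place of fluoro on an aromatic carbon of the shared core gives a number 8 percentage points lower from compound 2 to compound 3 (within the scatter), so the two groups cannot be told apart on this read-out at this position. The methoxy on the core therefore does not account for the low number of compound 1, and the large separation appears at the sulfonyl sulfur instead: 3-fluorophenyl in place of 3-chloro-4-methoxyphenyl gives a number 47 percentage points higher from compound 1 to compound 3 (beyond the scatter), with the methoxy on the core present on both sides. Nothing measured here explains either step.

The compounds shown leave open whether the chloro or the methoxy of the 3-chloro-4-methoxyphenyl group matters more, or only the two together. As far as these compounds go, it also remains open whether an amine or a carboxylic acid on that core carbon would read like fluoro and methoxy.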